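Methoxy in place of methyl at the compound 3 position

The source may report more compounds than this note shows. Statements on the series, on what has been measured and on what is new or still open speak of the compounds shown alone.

Compound 3 `Cc1cnc(-c2cc(Oc3ccc(S(C)(=O)=O)cc3)cc(OC(C)C)c2)[nH]c1=O` holds the second highest of three numbers in an ADME assay on microsomes from liver (Rattus norvegicus) for metabolic stability (on this read-out lower numbers stand for slow clearance and higher numbers for fast clearance), giving 189 mL/min/kg. Its neighbours lie within the scatter: compound 2 `CC(C)Oc1cc(Oc2ccc(S(C)(=O)=O)cc2)cc(-c2nccc(=O)[nH]2)c1` gives 105 mL/min/kg, and compound 1 `CC(C)Oc1cc(Oc2ccc(S(C)(=O)=O)cc2)cc(-c2cccc(=O)[nH]2)c1` gives 349 mL/min/kg, with a 1.8-fold lower number from compound 1 to compound 3 (0.27 log units; within the scatter) and a 1.8-fold higher number from compound 2 to compound 3 (0.26 log units; within the scatter). Among the compounds with values here, the one step beyond the scatter is a 3.3-fold lower number from compound 1 to compound 2 (0.52 log units; beyond the scatter), a change of the ring rather than of its substituent.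

Compound 4 `COc1cnc(-c2cc(Oc3ccc(S(C)(=O)=O)cc3)cc(OC(C)C)c2)[nH]c1=O` differs from compound 3 by methoxy in place of methyl on an aromatic carbon. Within the data shown here, the only step at this position is a 1.8-fold higher number from compound 2 to compound 3 (0.26 log units; within the scatter), within the scatter; no measured compound carries a methoxy here. A step no larger than the scatter is therefore expected in this assay, with a 1.0-fold higher number from compound 3 to compound 4 (0.00 log units; within the scatter) in either direction. Compound 4 is expected at 190 mL/min/kg, with a range of 95 mL/min/kg to 380 mL/min/kg.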

Compound 4, clearance: < 25.4 mL/min/kg
Compound 4: only a limit was reported; the forecaster's own chance of this, stated with the estimate: 0%; at least 7.4-fold (0.87 log units) between middle value and limit.
By their numbers in this assay, from the lowest: compounds 2, 3 and 1 (each within the scatter of the next, the first and the last beyond it). At a limit, below all of these: compound 4.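

In this assay, methoxy at this position, two atoms from the ring nitrogen, gives an at least 7.4-fold lower number from compound 3 to compound 4 (0.87 log units; beyond the scatter) and an at least 4.1-fold lower number from compound 2 to compound 4 (0.61 log units; beyond the scatter), whereas methyl in place of hydrogen stayed within the scatter, so this position is not indifferent to its substituent. The step from the core of compound 1 is an at least 13-fold lower number from compound 1 to compound 4 (1.13 log units; beyond the scatter), the only one here printed as large. Compound 4 stands at a limit of the assay, not a number: the limit of < 25.4 mL/min/kg in this assay, at which 1 of the 4 values shown sits.

From the compounds shown here alone, whether ethoxy, hydroxyl or an amine at this position would follow methoxy remains open. Also open, going by these compounds, is whether methoxy would give a similar step on the ring of compound 1.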